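Swapping a Ring Substituent in a Urea Series

The compounds below may be only part of what the source reports. "The series", "measured", "known", "first", "only" and "open" are said of these compounds alone.

Compound 2 `CC(C)(C)c1cc(NC(=O)Nc2ccc(Cl)cc2)n(-c2ccc(S(C)(=O)=O)cc2)n1` carries the shared core with a methylsulfonyl group on one of its outer aromatic rings. Among the compounds with values here, in an assay on isolated protein for inhibition of Ephrin type-A receptor 2 (Homo sapiens), read by thermal shift assay, tested at 10 uM (a higher number here means that the compound stabilises the target more against heat, a lower number that the compound stabilises the target less), compound 2 gives 1.2 degrees C, nominally the higher of the two numbers recorded so far, although the gap to its only neighbour lies within the scatter, so the two cannot really be ranked. That neighbour is compound 1 `CC(C)(C)c1cc(NC(=O)Nc2ccc(Cl)cc2)n(-c2ccc(C(F)(F)F)cc2)n1`, which in this assay gives 0.6 degrees C; the change a number 0.60 degrees C higher from compound 1 to compound 2 (within the scatter) is within the scatter. Compound 3 `CC(C)(C)c1cc(NC(=O)Nc2ccc(Cl)cc2)n(-c2ccc(NC(=O)C3CC3)cc2)n1` has not yet been measured. It differs from compound 2 in one place: (cyclopropylcarbonyl)amino in place of methylsulfonyl on an aromatic carbon. Within the data shown here, the single step measured so far, from compound 1 to compound 2, replaced the group at this same aromatic carbon and moved the reading by an amount within the scatter, so there is no sign yet that this position steers the melting-temperature shift. On that basis the expectation for compound 3 is a step of no change at the digits printed from compound 2 to compound 3 (within the scatter), which means nothing beyond the scatter. The estimated value for compound 3 in this assay is 1.2 degrees C, with a likely range from -0.3 degrees C to 2.7 degrees C.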

Compound 3, shift of the target's melting temperature: 3 degrees C
Estimate against measurement, compound 3: 1.8 degrees C below; measured number above the stated range.
By their numbers in this assay, from the lowest: compounds 1 and 2 (each within the scatter of the next); then compound 3.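

The aromatic carbon that carries this group can influence the reading after all, even though the swap from trifluoromethyl to methylsulfonyl did not show it. In this assay, placing (cyclopropylcarbonyl)amino there in place of methylsulfonyl gives a number 1.8 degrees C higher from compound 2 to compound 3 (beyond the scatter), and placing it there in place of trifluoromethyl gives a number 2.4 degrees C higher from compound 1 to compound 3 (beyond the scatter). Compared with methylsulfonyl, the entering group adds a hydrogen-bond donor and a three-membered ring and has more heavy atoms, but these features all arrive together in compound 3, and no data shown here explain the rise.

Still open, going by these compounds, is which part of the (cyclopropylcarbonyl)amino group matters: the amide hydrogen, the carbonyl or the cyclopropyl ring. A simple amine on this aromatic carbon, or an amide with a longer chain in place of the cyclopropyl ring, would help to tell these parts apart and show how much of the step from either earlier compound each one accounts for.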